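Extending the ether chain on a flavone-type core

The source may hold more compounds than are shown below. What is called first, only, known or untested is meant among the compounds shown, and "the series" means these compounds.

Of the compounds shown here, two built on one shared core have been measured so far. Compound 1 `O=c1c(-c2ccc(O)cc2)coc2cc(OCCCBr)ccc12` gives 150 nM in an assay on isolated protein (Cricetulus griseus) for inhibition of Monoamine oxidase (Homo sapiens); on this read-out higher numbers stand for weaker inhibition and lower numbers for stronger inhibition. For the measured compounds named here, compound 2 `C=CCOc1ccc2c(=O)c(-c3ccc(O)cc3)coc2c1` gives 450 nM in this assay, which places it as the higher of the two numbers, and the only measured step shows a 3.0-fold higher number from compound 1 to compound 2 (0.48 log units; beyond the scatter). The untested compound 3 `O=C(O)CCCCCCOc1ccc2c(=O)c(-c3ccc(O)cc3)coc2c1` differs from compound 2 in one place: 5-carboxypentyl in place of vinyl on a saturated chain carbon bound to an oxygen on an aromatic ring.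

Going by the values given here, the single measured step bears on this change only loosely, since it pairs a shorter chain with a longer one carrying bromine, while compound 3 carries a longer chain ending in a carboxylic acid. Among the compounds with values here, that step was of modest size and ran toward a higher number when the chain was shortened, so returning to a longer chain is expected to pull the number back down somewhat, though the acid group is new here and no measured step tells how it behaves. For compound 3 the expected value in this assay is 300 nM, with a range from 100 nM to 1200 nM, corresponding to an estimated step of a 1.5-fold lower number from compound 2 to compound 3 (0.18 log units; within the scatter).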

Compound 3, half-maximal inhibitory concentration: 2100 nM
Compound 3: middle estimate off by 7.0-fold (0.85 log units), on the low side; the whole stated range lies below it.
By their numbers in this assay, from the lowest: compound 1; then compound 2; then compound 3.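

In this assay the result shows that a longer chain at this place does not by itself lower the number: 5-carboxypentyl in place of vinyl gives a 4.7-fold higher number from compound 2 to compound 3 (0.67 log units; beyond the scatter) and so moves toward weaker inhibition. The end of the chain also matters, since 3-carboxypropyl in place of bromo gives a 14-fold higher number from compound 1 to compound 3 (1.15 log units; beyond the scatter) and this is the largest step among the three compounds, which also do not follow chain length in a steady order, as compound 1, with the bromo-ended chain of middle length, has the lowest number. Nothing available here explains why the chain ending in a carboxylic acid sits at the weak end of this set.

Still open, on these data alone, is whether the loss follows from the carboxylic acid itself or from the length of the chain that carries it, a question that a plain hexyl chain or a chain of the same length ending in bromine would help to settle. As far as these compounds go, it is equally open how a methyl ester, an amide or an amine at the chain end would compare with the acid at this place.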